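A few compounds are considered here, and "the series" means these few. Any claim that something is new, unique, unknown or untested is made for them only; others in the source may bear on it.

Measured so far:
Compound 1 `COc1ncc(-c2ccc3c(c2)N(c2ccc(C)cc2)C(=O)CO3)cc1NS(=O)(=O)c1ccc(F)cc1` gives 28300 nM in a functional assay on HepG2 cells (Homo sapiens) for antiproliferative activity, read by MTT assay, with a stated time of 72 h; on this read-out higher numbers stand for weaker inhibition and lower numbers for stronger inhibition.
Compound 3 `COc1ccc(N2C(=O)COc3ccc(-c4cnc(OC)c(NS(=O)(=O)c5ccc(F)cc5)c4)cc32)cc1` gives 13100 nM in this assay.
Compound 2 `Cc1ccc(N2C(=O)COc3ccc(-c4cnc5ccccc5c4)cc32)cc1` reaches only a limit, > 40000 nM, in this assay, not a number.

Among the measured compounds shown here, the one measured step, a 2.2-fold lower number from compound 1 to compound 3 (0.33 log units; beyond the scatter), alters a different position from the change considered here. Compound 2 stands at the upper end of the numbers shown, at the limit of > 40000 nM in this assay, at which 1 of the 3 values shown sits, so its value is known only as a limit. Compound 4 `O=C1COc2ccc(-c3cnc4ccccc4c3)cc2N1` differs from compound 2 by hydrogen in place of 4-methylphenyl on an amide-type nitrogen in a ring. For the measured compounds named here, no measured step bears on this change, so the steps give no direction for it; the only anchor is compound 2 at its limit > 40000 nM. The expected step for compound 4 in this assay is therefore a number no higher from compound 2 to compound 4 (the limit leaves the size open), none beyond the scatter, and the estimate for compound 4 is 40000 nM, within 15000 nM to 100000 nM.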

Compound 4, half-maximal inhibitory concentration: 26300 nM
Beside the measured number, compound 4's estimate is 1.5-fold (0.18 log units) above it; the measured number falls inside the stated range.
By their numbers in this assay, from the lowest: compounds 3, 4 and 1 (each within the scatter of the next, the first and the last beyond it). At a limit, above all of these: compound 2.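

Compound 2 sits at a limit, not a number: the limit of > 40000 nM in this assay, at which 1 of the 4 values shown sits. Hydrogen in place of 4-methylphenyl on the amide-type nitrogen in a ring gives an at least 1.5-fold lower number from compound 2 to compound 4 (0.18 log units; that floor lies within the scatter), so the 4-methylphenyl group is not required for a measured number at this position. Only the floor of this step is known, not its true size.

Still open, from the compounds shown here alone, is how an ethyl group, or a longer chain ending in an amine, on this nitrogen would read. Also open, going by these compounds, is whether the same change would act alike on the core of compound 1.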